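The compounds below may be only part of what the source reports. "The series", "measured", "known", "first", "only" and "open" are said of these compounds alone.

Among the measured compounds shown here, compound 2 `Cc1ccc(-c2nnc(-c3cccc(S(N)(=O)=O)c3)o2)cc1` stands at the lower of the two numbers so far measured in an assay on cells for inhibition of Amine oxidase [flavin-containing] B (Homo sapiens), read by fluorescence and spectrophotometry, using microsomes, with a stated time of 20 min (a lower number here means a stronger inhibitor, a higher number a weaker inhibitor), where compound 2 gives 571 nM. For the measured compounds named here, its only neighbour is compound 1 `NS(=O)(=O)c1cccc(-c2nnc(-c3ccc(F)cc3)o2)c1`, which in this assay gives 975 nM; the step of a 1.7-fold lower number from compound 1 to compound 2 (0.23 log units; within the scatter) therefore lies within the scatter, so the two compounds cannot be ranked against each other. Compound 3 `NS(=O)(=O)c1cccc(-c2nnc(-c3ccc(Cl)cc3)o2)c1` differs from compound 2 by chloro in place of methyl on an aromatic carbon. Going by the values given here, the one measured step that bears on this position, a 1.7-fold lower number from compound 1 to compound 2 (0.23 log units; within the scatter), exchanged two small groups at the same place without moving the number beyond the scatter, and nothing else in the data speaks to chloro at this position. On that basis the change from compound 2 to compound 3 is expected to give no step beyond the scatter in this assay, a 1.2-fold higher number from compound 2 to compound 3 (0.09 log units; within the scatter). Compound 3 is accordingly estimated at 700 nM, in a range from 300 nM to 1600 nM.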

Compound 3, half-maximal inhibitory concentration: 210 nM
For compound 3 the middle estimate is 3.3-fold (0.52 log units) above the measured one; measured number outside the range, below it.
By their numbers in this assay, from the lowest: compound 3; then compounds 2 and 1 (each within the scatter of the next).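

In this assay the group at this position now makes a difference: chloro in place of methyl gives a 2.7-fold lower number from compound 2 to compound 3 (0.43 log units; beyond the scatter) and chloro in place of fluoro gives a 4.6-fold lower number from compound 1 to compound 3 (0.67 log units; beyond the scatter) and both steps lie beyond the scatter, whereas the earlier exchange of fluoro for methyl did not. Small groups at this position are therefore not interchangeable, and chloro stands apart from both methyl and fluoro, which themselves remain within the scatter of each other. Nothing available accounts for why chloro differs from the other two groups.

The compounds shown leave open whether bromo, trifluoromethyl, methoxy or an amine at this position would match chloro or fall back towards methyl and fluoro. They also leave open whether chloro would give the same result on another carbon of this ring.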